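Fluorophenyl isomers in an antiproliferative series

A few compounds are considered here, and "the series" means these few. Any claim that something is new, unique, unknown or untested is made for them only; others in the source may bear on it.

Compound 3 `COc1cc(-n2cnc3ccc(-c4cccc(F)c4)cc32)cc(OC)c1OC` was measured in a functional assay on A549 cells (Homo sapiens) for antiproliferative activity, read by MTT assay, with a stated time of 72 h (on this read-out lower numbers stand for stronger inhibition and higher numbers for weaker inhibition), where compound 3 gives 5270 nM. Among the three measured compounds this number is the second highest; compound 1 `CCOc1ccc(-c2ccc3ncn(-c4cc(OC)c(OC)c(OC)c4)c3c2)cc1` gives 8550 nM and compound 2 `COc1cc(-n2cnc3ccc(-c4ccccc4)cc32)cc(OC)c1OC` gives 3060 nM, and both lie within the scatter of compound 3. The step to compound 4 `COc1cc(-n2cnc3ccc(-c4ccc(F)cc4)cc32)cc(OC)c1OC` is 4-fluorophenyl in place of 3-fluorophenyl on an aromatic carbon. Going by the values given here, no measured step moves the fluorine itself; the nearest comparisons are a 1.7-fold higher number from compound 2 to compound 3 (0.24 log units; within the scatter) and a 1.6-fold lower number from compound 1 to compound 3 (0.21 log units; within the scatter), both within the scatter. The step of a 2.8-fold lower number from compound 1 to compound 2 (0.45 log units; beyond the scatter) concerns a different group. Compound 4 is therefore expected to show a 1.1-fold lower number from compound 3 to compound 4 (0.02 log units; within the scatter), with no change beyond the scatter. The estimate for compound 4 is 5000 nM, with a range from 2000 nM to 12000 nM.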

Compound 4, half-maximal inhibitory concentration: 6740 nM
The estimate for compound 4 lay 1.3-fold (0.13 log units) below the measured number; measured number inside the range.
By their numbers in this assay, from the lowest: compounds 2, 3, 4 and 1 (each within the scatter of the next, the first and the last beyond it).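

Moving the fluorine from 3-fluorophenyl to 4-fluorophenyl gives a 1.3-fold higher number from compound 3 to compound 4 (0.11 log units; within the scatter) and so does not separate the two isomers. Fluoro in place of hydrogen, however, gives a 2.2-fold higher number from compound 2 to compound 4 (0.34 log units; beyond the scatter) and is the first fluorine step to lie beyond the scatter, though only modestly. Fluoro in place of ethoxy gives a 1.3-fold lower number from compound 1 to compound 4 (0.10 log units; within the scatter) and so does not separate these two groups.

On these data alone, whether an amine or a carboxylic acid on the same phenyl ring would behave differently remains open. Nothing available explains these steps.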